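Sulfonyl chain length and acid dissociation in one series

The source may hold more compounds than are shown below. What is called first, only, known or untested is meant among the compounds shown, and "the series" means these compounds.

Compound 1 `CCCCS(=O)(=O)c1ccc(O)c(C(=O)Nc2ccc(Br)cc2)c1` and compound 2 `CCCCCCCCCCS(=O)(=O)c1ccc(O)c(C(=O)Nc2ccc(Br)cc2)c1` share a core and differ only in the chain on the sulfonyl sulfur. In a physicochemical assay for acid dissociation, compound 1 gives 5.2, and compound 2 gives 5.2. The step of no change at the digits printed from compound 2 to compound 1 (within the scatter) comes from the change (hydrogen in place of hexyl on a saturated chain carbon, four bonds along the chain from a sulfonyl sulfur). Compound 3 `CCCCCCCCCCCCS(=O)(=O)c1ccc(O)c(C(=O)Nc2ccc(C(F)(F)F)cc2)c1` gives 6.2 in this assay; the difference between its core and the core of compound 2 is not broken down here. Compound 4 `CCCCCCS(=O)(=O)c1ccc(O)c(C(=O)Nc2ccc(C(F)(F)F)cc2)c1` is not yet measured in this assay. It arises from compound 3 by hydrogen in place of hexyl on a saturated chain carbon, six bonds along the chain from a sulfonyl sulfur. This is the same kind of change as that from compound 2 to compound 1, but the place differs: there the hexyl left a carbon four bonds along the chain from the sulfonyl sulfur, here six bonds along the chain. Because the earlier change gave no change at the digits printed from compound 2 to compound 1 (within the scatter), the step of no change at the digits printed from compound 3 to compound 4 (within the scatter) is expected to be of similar size. Compound 4 is therefore estimated at 6.2, between 5.8 and 6.6.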

Compound 4, acid dissociation constant: 6.2
Compound 4: middle estimate and measured number agree at the digits printed, within the range that was stated.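

In this assay the loss of hexyl gives no change at the digits printed from compound 3 to compound 4 (within the scatter) and, on the other core, gives no change at the digits printed from compound 2 to compound 1 (within the scatter) as well, so across these two pairs the change carries from one core to the other with no step beyond the scatter. This rests on two pairs only, with the hexyl leaving a different place along the chain in each, and it does not show that the change would read the same on any further core. No measurement at hand bears on the reason for this result.

Open, from the compounds shown here alone, is whether an amine or a carboxylic acid in place of hexyl would also leave the number in this assay unmoved. A chain longer than any shown is equally open.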